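Replacing a guanidine-bearing side chain with a tert-butyl ester

A few compounds are considered here, and "the series" means these few. Any claim that something is new, unique, unknown or untested is made for them only; others in the source may bear on it.

Measured compounds:
compound 1 `CCC[C@H](NCc1ccc(C(=N)N)cc1)C(=O)[C@@H](CCCNC(=N)N)NS(=O)(=O)Cc1ccccc1` gives 15 nM
compound 2 `N=C(N)NCCC[C@H](NCc1ccc(C(=N)N)cc1)C(=O)[C@@H](CCCNC(=N)N)NS(=O)(=O)Cc1ccccc1` gives 457 nM

In an assay on isolated protein for inhibition of transmembrane protease serine 11D (Homo sapiens), read by fluorescence (on this read-out lower numbers stand for stronger inhibition and higher numbers for weaker inhibition), compound 2 stands at the highest of the two numbers; its nearest neighbour is compound 1, a step away of a 30-fold higher number from compound 1 to compound 2 (1.48 log units; beyond the scatter). Compound 3 `CC(C)(C)OC(=O)C[C@H](NCc1ccc(C(=N)N)cc1)C(=O)[C@@H](CCCNC(=N)N)NS(=O)(=O)Cc1ccccc1` differs from compound 2 by a group of 7 heavy atoms (5 carbon, 2 oxygen; no ring) in place of a group of 6 heavy atoms (3 carbon, 3 nitrogen; no ring), on a saturated chain carbon, two bonds along the chain from an amine nitrogen and a carbonyl carbon. Among the compounds with values here, the only measured step that bears on this change is the one from compound 1 to compound 2, which was large, and it concerns the same region of the shared core: the side chain that carries the guanidine. Compound 3 loses that guanidine-containing chain entirely and gains a group that, like the propyl chain of compound 1, carries no hydrogen-bond donors. The number for compound 3 is therefore expected to move back toward the value of compound 1, by an estimated step of a 7.6-fold lower number from compound 2 to compound 3 (0.88 log units; beyond the scatter). The estimate for compound 3 in this assay is 60 nM, with a range from 15 nM to 300 nM.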

Compound 3, inhibition constant: 512 nM
Compound 3: middle estimate off by 8.5-fold (0.93 log units), on the low side; the whole stated range lies below it.
By their numbers in this assay, from the lowest: compound 1; then compounds 2 and 3 (each within the scatter of the next).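

In this assay, tert-butoxycarbonyl on the saturated chain carbon, two bonds along the chain from an amine nitrogen and a carbonyl carbon, gave a result that could not be told apart from that of the guanidine-bearing group (a 1.1-fold higher number from compound 2 to compound 3 (0.05 log units; within the scatter)). Both groups stand well away from the compound with the short chain, and a group with 0 hydrogen-bond donors did not restore the number of compound 1 (a 34-fold higher number from compound 1 to compound 3 (1.53 log units; beyond the scatter)), so the guanidine is not required for the large step seen at this position. No measurement shown accounts for this result.

The compounds shown leave open how a carboxylic acid or an amine on the same chain would compare. They also leave open whether a chain of intermediate length, such as butyl, would stand nearer compound 1 or nearer compound 2.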